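The source may report more compounds than this note shows. Statements on the series, on what has been measured and on what is new or still open speak of the compounds shown alone.

Measured so far in an ADME assay on U-937 cells (Homo sapiens) for inhibition, read by CellTiter-Glo, with a stated time of 72 h; a lower number here means a stronger inhibitor of growth, a higher number a weaker inhibitor of growth:
- compound 1 `Cc1ccc(Nc2ncc3c(n2)N(C)C(=O)N(c2cc(NC(=O)c4ccc(C)c(C(F)(F)F)c4)ccc2C)C3)cn1`: 19400 nM
- compound 2 `Cc1ccc(Nc2ncc3c(n2)N(C)C(=O)N(c2cc(NC(=O)c4ccc(-n5cccc5)c(C(F)(F)F)c4)ccc2C)C3)cn1`: > 25000 nM

Compound 2 stands at > 25000 nM, which is a limit of this assay and not a number. Compound 3 `Cc1ccc(Nc2ncc3c(n2)N(C)C(=O)N(c2cc(NC(=O)c4ccc(CN5CCC(N(C)C)C5)c(C(F)(F)F)c4)ccc2C)C3)cn1` has not yet been measured. It differs from compound 2 at a single place: (3-(dimethylamino)pyrrolidin-1-yl)methyl in place of 1H-pyrrol-1-yl on an aromatic carbon Here (3-(dimethylamino)pyrrolidin-1-yl)methyl stands in place of 1H-pyrrol-1-yl on an aromatic carbon, ortho to a trifluoromethyl group.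

Among the measured compounds shown here, only one measured step bears on this place, an at least 1.2-fold higher number from compound 1 to compound 2 (0.11 log units; that floor lies within the scatter). It sets no firm size for a change here. The nearest real number is that of compound 1, 19400 nM, so compound 3 is expected to fall in the same high range, with a modest move towards a lower number in this assay. The estimated step is an at least 2.5-fold lower number from compound 2 to compound 3 (0.39 log units; beyond the scatter). For compound 3 the expected value is 10000 nM, with an estimated range from 2000 nM to 30000 nM.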

Compound 3, concentration for 50% growth inhibition: 1970 nM
Compound 3: middle estimate off by 5.1-fold (0.71 log units), on the high side, outside the stated range (below it).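

In this assay, this aromatic carbon, ortho to a trifluoromethyl group, had shown no change beyond the scatter, but (3-(dimethylamino)pyrrolidin-1-yl)methyl in place of 1H-pyrrol-1-yl gives an at least 12-fold lower number from compound 2 to compound 3 (1.10 log units; beyond the scatter). Measured against the methyl group instead, the same place gives a 9.8-fold lower number from compound 1 to compound 3 (0.99 log units; beyond the scatter), so the position does respond to the group it carries. The first of these steps is only a floor, because compound 2 carries a limit of the assay and not a number: the limit of > 25000 nM in this assay, at which 1 of the 3 values shown sits.

The compounds shown leave open whether the dimethylamino group or the pyrrolidine ring goes with this shift, and a plain pyrrolidin-1-ylmethyl group or a dimethylaminomethyl group at this place would separate the two. On these data alone, the trifluoromethyl group is the same in all three compounds, so whether the shift depends on it also stays open.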